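Swapping a pyrazole ester for a pyridine ester

The source may report more compounds than this note shows. Statements on the series, on what has been measured and on what is new or still open speak of the compounds shown alone.

Measured so far:
- compound 1 `CC(=O)Oc1ccccc1C(=O)O[C@H]1CO[C@H]2[C@@H]1OC[C@H]2OC(=O)c1ccnn1C`: 0.0963 h
- compound 2 `COc1cccc(C(=O)O[C@@H]2CO[C@H]3[C@@H]2OC[C@@H]3OC(=O)c2ccccc2OC(C)=O)c1`: 0.0525 h
- compound 3 `CC(=O)Oc1ccccc1C(=O)O[C@H]1CO[C@H]2[C@@H]1OC[C@H]2OC(=O)c1ccc(-c2ccccc2)cc1`: > 0.333 h

Of the compounds shown here, three sharing one core have been tested in an ADME assay on a cell-free system (plasma, Homo sapiens) for metabolic stability, with Plasma (Rattus norvegicus) as the target, read by HPLC, at pH 7.4; a lower number here means that the compound disappears faster, a higher number that the compound lasts longer. Compound 1 and compound 2 give plain numbers that sit within the usual scatter of each other, since a 1.8-fold lower number from compound 1 to compound 2 (0.26 log units; within the scatter). Compound 3 is different: its reading is only a limit of the assay, (the limit of > 0.333 h in this assay, at which 1 of the 3 values shown sits). Against that limit, an at least 3.4-fold higher number from compound 1 to compound 3 (0.53 log units; beyond the scatter) and an at least 6.3-fold higher number from compound 2 to compound 3 (0.80 log units; beyond the scatter) are the only steps clearly beyond the scatter.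

The new compound 4 `CC(=O)Oc1ccccc1C(=O)O[C@H]1CO[C@H]2[C@@H]1OC[C@H]2OC(=O)c1cccnc1` has not yet been measured. It differs from compound 1 in one place: pyridin-3-yl in place of 1-methyl-1H-pyrazol-5-yl on a carbonyl carbon. Among the compounds with values here, no measured step swaps the same pair of groups, so the nearest guide is the behaviour of compound 1 itself together with the small step to compound 2, where a differently substituted aromatic ester left the half-life essentially unchanged. The large gain seen with compound 3 involves a much bigger group and does not carry over directly.

Compound 4 is therefore expected to stay close to compound 1, with a 1.0-fold higher number from compound 1 to compound 4 (0.02 log units; within the scatter) judged to lie within the scatter. The estimate for compound 4 in this assay is 0.1 h, spanning from 0.05 h to 0.25 h.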

Compound 4, half-life: 0.0232 h
Estimate against measurement, compound 4: 4.3-fold (0.63 log units) above, and the stated range ends above it.
By their numbers in this assay, from the lowest: compound 4; then compounds 2 and 1 (each within the scatter of the next). At a limit, above all of these: compound 3.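

In this assay, this carbonyl carbon proves sensitive even to a swap between two small aromatic rings with the same number of heavy atoms: pyridin-3-yl gives a 4.2-fold lower number from compound 1 to compound 4 (0.62 log units; beyond the scatter), and against the 3-methoxyphenyl ester it gives a 2.3-fold lower number from compound 2 to compound 4 (0.35 log units; beyond the scatter). Until now, only the much larger 4-phenylphenyl group had moved the half-life beyond the scatter, whereas the new spread at the short-lived end shows that group size is not the whole story, and the full range among these esters now reaches an at least 14-fold lower number from compound 3 to compound 4 (1.15 log units; beyond the scatter). That range has no fixed upper end, since the reading for compound 3 is only a limit of the assay: the limit of > 0.333 h in this assay, at which 1 of the 4 values shown sits.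

The half-life alone does not show which of the ester groups on the shared core is lost first, so the compounds here cannot explain why the pyridin-3-yl ester disappears faster. On these data alone, it also remains open how the half-life would respond to a saturated ring such as piperidine at this carbonyl carbon, or to an aromatic ring carrying an amine or a carboxylic acid.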